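The source may hold more compounds than are shown below. What is called first, only, known or untested is meant among the compounds shown, and "the series" means these compounds.

Measured in an ADME assay on Akata cells (Homo sapiens) for cytotoxicity, with a stated time of 7 days; a higher number here means that more compound is tolerated, a lower number that less compound is tolerated:
compound 1 `CNc1nc(N)nc2c1ncn2/C=C1/CC1(CO)CO`: > 24000 nM
compound 2 `CCCCCCCCOc1nc(N)nc2c1ncn2/C=C1/CC1(CO)CO`: > 20000 nM
compound 3 `CCCCCOc1nc(N)nc2c1ncn2/C=C1/CC1(CO)CO`: > 20000 nM

All three entries are limits of the assay, not numbers. Compound 3 is known only through its limit of > 20000 nM. The values shown gather at the limit of > 20000 nM in this assay, at which 2 of the 3 values shown sit. The remaining one stands at the limit of > 24000 nM in this assay, at which 1 of the 3 values shown sits.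

Next in the series is compound 4 `CC(C)Sc1nc(N)nc2c1ncn2/C=C1/CC1(CO)CO`, which has no measurement yet. The change is isopropylsulfanyl in place of pentyloxy on an aromatic carbon.

Two measured steps change the group on this same carbon: a step that the two limits leave unreadable from compound 1 to compound 3 and a step that the two limits leave unreadable from compound 1 to compound 2. A third changes the length of the alkoxy chain: a step that the two limits leave unreadable from compound 2 to compound 3. None of the three gives a size, so none offers a direction for the new step in this assay. Methylamino, octyloxy and pentyloxy all ended in a limit, with no exception among the measured compounds, and the same outcome is therefore the likeliest one here. No step beyond the usual scatter is expected in this assay. The expected step is a number no higher from compound 3 to compound 4 (the limit leaves the size open). The estimate for compound 4 is 20000 nM, with an expected range of 8000 nM to 40000 nM.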

Compound 4, half-maximal cytotoxic concentration: > 20000 nM
Compound 4: a limit, no number; the forecaster's own chance of this, stated with the estimate: 80%; the middle value lies on the limit itself.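

In this assay compound 4 gives > 20000 nM, a limit and not a number. The steps to compound 4 from compound 1, compound 2 and compound 3 cannot be read, as each joins two limits. The compounds shown leave open the concentration at which any of the four becomes cytotoxic, and whether methylamino, octyloxy, pentyloxy and isopropylsulfanyl differ at all.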